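A Chlorine Added to the Most Active Compound

This account rests on a few compounds, and the source may have more. Where it says the series, first, only, none or still open, it means among the compounds named here.

The three compounds measured so far, in a functional assay on MGC-803 cells (Homo sapiens) for antiproliferative activity, read by CCK-8 assay, with a stated time of 72 h, tested at 8 uM; on this read-out higher numbers stand for a stronger effect at the one concentration tested and lower numbers for a weaker effect:

- compound 1, `Nc1ccccc1NC(=O)c1ccc(CSC(=S)N2CCN(C(c3ccccc3)c3ccccc3)CC2)cc1`, gives 9.9%
- compound 2, `Nc1ccccc1NC(=O)c1ccc(CSC(=S)N2CCc3ccccc32)cc1`, gives 87%
- compound 3, `COc1ccc(N2CCN(C(=S)SCc3ccc(C(=O)Nc4ccccc4N)cc3)CC2)cc1`, gives 22.9%

Compound 2 stands highest of these three numbers. The nearest to it is compound 3, and that gap lies beyond the usual scatter; the furthest is compound 1, again beyond the scatter. On these numbers compound 2 is the strongest of the three.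

Compound 4, `Nc1ccccc1NC(=O)c1ccc(CSC(=S)N2CCc3cc(Cl)ccc32)cc1`, is built from compound 2 by one change: chloro in place of hydrogen on an aromatic carbon. For the measured compounds named here, no measured pair in this set differs only by such a chloro, so there is no direct step to lean on. The change is small in count, and the rest of compound 2 is kept, so the expected step of a number 5 percentage points lower from compound 2 to compound 4 (within the scatter) is one that stays within the scatter, with no clear direction. Compound 4 is therefore estimated to give 82% in this assay, within a range from 58% to 96%.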

Compound 4, a percentage reported as inhibition, at one concentration (the size of the read-out at that concentration, not a potency): 82.2%
Beside the measured number, compound 4's estimate is 0.2 percentage points below it; the range from low to high includes it.
By their numbers in this assay, from the lowest: compound 1; then compound 3; then compounds 4 and 2 (each within the scatter of the next).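

In this assay, for the compounds shown here, chloro in place of hydrogen on an aromatic carbon gives a step of a number 4.8 percentage points lower from compound 2 to compound 4 (within the scatter), the first direct reading of a single change in this set. The earlier compounds shown here differ from one another in more than one place and could not show this. Here, 5-chloro-2,3-dihydro-1H-indol-1-yl keeps the high read-out seen with 2,3-dihydro-1H-indol-1-yl, so this aromatic carbon can carry a chlorine without a step beyond the scatter. Nothing measured here explains why the read-out holds.

Going by these compounds, whether this tolerance extends to an amine, a carboxylic acid or a bromine on the same carbon remains open. Also open, on these data alone, is how chloro would read on the other carbons of that ring, and whether compound 4 would match compound 2 at other concentrations.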